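Ortho Hydroxy Analogue of a Naphthyloxyacetyl Hydrazone: Expected Cytotoxicity

The source may report more compounds than this note shows. Statements on the series, on what has been measured and on what is new or still open speak of the compounds shown alone.

Compound 1 `O=C(COc1cccc2ccccc12)N/N=C/c1ccc(O)cc1` 26.5 ug/mL
Compound 2 `O=C(COc1cccc2ccccc12)N/N=C/c1ccc(Cl)cc1` 87.6 ug/mL
Compound 3 `O=C(COc1cccc2ccccc12)N/N=C/c1ccccc1Cl` 56.2 ug/mL

In an ADME assay on MT4 cells (Homo sapiens) for cytotoxicity, read by MTT assay, with a stated time of 4 days (on this read-out higher numbers stand for lower toxicity in this test and lower numbers for higher toxicity in this test), compound 3 has the second highest of the three numbers: its gap to compound 2 is within the scatter, while its gap to compound 1 is beyond it, as a 2.1-fold higher number from compound 1 to compound 3 (0.33 log units; beyond the scatter) shows. Compound 4 `O=C(COc1cccc2ccccc12)N/N=C/c1ccccc1O` differs from compound 3 by hydroxy in place of chloro on an aromatic carbon. Among the measured compounds shown here, the one measured step that bears on this exchange is a 3.3-fold higher number from compound 1 to compound 2 (0.52 log units; beyond the scatter), which runs in the opposite direction and sits on a different carbon of the ring. Compound 4 is therefore expected to give a lower number than compound 3, by roughly a 2.6-fold lower number from compound 3 to compound 4 (0.41 log units; beyond the scatter), though the different place of the change leaves room for a smaller shift. The estimate for compound 4 is 22 ug/mL, with a range from 9 ug/mL to 50 ug/mL.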

Compound 4, half-maximal cytotoxic concentration: 5.19 ug/mL
Estimate against measurement, compound 4: 4.2-fold (0.63 log units) above; the whole stated range lies above it.
By their numbers in this assay, from the lowest: compound 4; then compound 1; then compounds 3 and 2 (each within the scatter of the next).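

In this assay, among the compounds shown here, hydroxy in place of chloro on an aromatic carbon ortho to a large group brings a much larger shift than the earlier compounds showed, an 11-fold lower number from compound 3 to compound 4 (1.03 log units; beyond the scatter). Moving the hydroxy also counts, a 5.1-fold lower number from compound 1 to compound 4 (0.71 log units; beyond the scatter), and compound 4 gives the lowest number of the set, with a 17-fold lower number from compound 2 to compound 4 (1.23 log units; beyond the scatter). The size of the exchange therefore depends on where it sits: the same change on two cores in this assay, a 3.3-fold higher number (0.52 log units; beyond the scatter) from compound 1 to compound 2 and an 11-fold higher number (1.03 log units; beyond the scatter) from compound 4 to compound 3, 3.3-fold (0.52 log units) apart, beyond the scatter of two such steps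

The compounds shown leave open whether an amine or a methoxy group on that same carbon would give a number nearer to that of hydroxy or of chloro.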